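Swapping tert-butyl for methyl on the shared core

The compounds below may be only part of what the source reports. "The series", "measured", "known", "first", "only" and "open" are said of these compounds alone.

Measured so far:
- compound 1 `CC(=O)c1ccc(-c2nccc3[nH]c(C(C)(C)O)cc23)cc1` — "not determined" (no result reported) in an ADME assay on U2OS cells (Homo sapiens) for cytotoxicity; a higher number here means that more compound is tolerated, a lower number that less compound is tolerated
- compound 2 `CC(C)(O)c1cc2c(-c3ccc(C(F)(F)F)cc3)nccc2[nH]1` — 72300 nM
- compound 3 `CC(C)(C)c1ccc(-c2nccc3[nH]c(C(C)(C)O)cc23)cc1` — 35300 nM

Compound 3 stands at the lowest of the two numbers in this assay, meaning that of the two it is the compound of which least is tolerated by the cells. Its nearest neighbour is compound 2, and the step of a 2.0-fold lower number from compound 2 to compound 3 (0.31 log units; beyond the scatter) is modest but beyond the usual scatter. Compound 1 carries an acetyl group in the same position and adds no number to compare with.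

Compound 4 `Cc1ccc(-c2nccc3[nH]c(C(C)(C)O)cc23)cc1` is the next compound to be measured. It differs from compound 3 in one place:

methyl in place of tert-butyl on an aromatic carbon

Within the data shown here, only one measured step bears on this change, the one from compound 2 to compound 3, where tert-butyl replaced trifluoromethyl and the number fell by a modest amount. Now tert-butyl itself leaves and a smaller group, methyl, enters. With a single step to lean on, no strong direction can be claimed; a small movement back toward the number of compound 2, or none beyond the scatter, seems most likely. Compound 4 is therefore estimated to show a 1.4-fold higher number from compound 3 to compound 4 (0.15 log units; within the scatter), with an expected value of 50000 nM and a range from 25000 nM to 100000 nM.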

Compound 4, half-maximal cytotoxic concentration: 38500 nM
Beside the measured number, compound 4's estimate is 1.3-fold (0.11 log units) above it, and the stated range covers the measured number.
By their numbers in this assay, from the lowest: compounds 3, 4 and 2 (each within the scatter of the next, the first and the last beyond it).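

In this assay, shrinking the group on the aromatic carbon from tert-butyl, with 4 heavy atoms, to methyl, with 1 heavy atom, gives a 1.1-fold higher number from compound 3 to compound 4 (0.04 log units; within the scatter), so this large difference in group size leaves no readable change between these two compounds. Methyl in place of trifluoromethyl gives a 1.9-fold lower number from compound 2 to compound 4 (0.27 log units; within the scatter), which places compound 4 within the scatter of both compound 2 and compound 3; the earlier step of a 2.0-fold lower number from compound 2 to compound 3 (0.31 log units; beyond the scatter) therefore stands as the only separation among the three, and it is a narrow one. Nothing measured here explains these numbers or the lack of a clear change.

The three numbers cover only tert-butyl, methyl and trifluoromethyl, and compound 1, with its acetyl group, gives "not determined" (no result reported) and so cannot be placed among them. From the compounds shown here alone, it remains open whether an amine, a carboxylic acid or a longer chain in the same position would shift the number clearly beyond the scatter, or whether the cells would respond to this position as little as they do across these three groups.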